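Weighing a 2-Bromophenyl Analogue Against Three Measured Halogen Variants

The source may report more compounds than this note shows. Statements on the series, on what has been measured and on what is new or still open speak of the compounds shown alone.

Of the compounds shown here, three sharing one core have been measured in a functional assay on A549 cells (Homo sapiens) for inhibition, read by CCK-8 assay; a lower number here means a stronger inhibitor, a higher number a weaker inhibitor. Compound 1 `Oc1ccccc1/C=N/c1nnc(SCc2nnc(-c3ccccc3)o2)s1` gives 4110 nM. Compound 2 `Oc1ccccc1/C=N/c1nnc(SCc2nnc(-c3ccc(F)cc3)o2)s1`, carrying a fluoro group, gives 20100 nM, and compound 3 `Oc1ccccc1/C=N/c1nnc(SCc2nnc(-c3ccc(Cl)cc3)o2)s1`, carrying a chloro group, gives 30100 nM. Compound 3 stands highest of the three: its nearest neighbour is compound 2, within the scatter, while compound 1 lies furthest, beyond the scatter. The steps of a 4.9-fold higher number from compound 1 to compound 2 (0.69 log units; beyond the scatter) and a 7.3-fold higher number from compound 1 to compound 3 (0.86 log units; beyond the scatter) show that either halogen raises the number modestly relative to the bare phenyl, whereas a 1.5-fold higher number from compound 2 to compound 3 (0.18 log units; within the scatter) stays within the scatter.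

Compound 4 `Oc1ccccc1/C=N/c1nnc(SCc2nnc(-c3ccccc3Br)o2)s1` has not yet been measured. It differs from compound 3 by 2-bromophenyl in place of 4-chlorophenyl on an aromatic carbon. Among the measured compounds shown here, no measured step covers a bromo group or a 2-bromophenyl at all; the steps that bear on this change only show that a halogenated phenyl gives a higher number than the bare phenyl of compound 1, and that exchanging one halogen for another, as in a 1.5-fold higher number from compound 2 to compound 3 (0.18 log units; within the scatter), changes little. On that basis compound 4 is expected to stay near compound 3, with a step of a 1.5-fold lower number from compound 3 to compound 4 (0.18 log units; within the scatter) that should remain within the scatter. The estimate for compound 4 is 20000 nM, in a range from 5000 nM to 80000 nM.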

Compound 4, half-maximal inhibitory concentration: 7150 nM
Beside the measured number, compound 4's estimate is 2.8-fold (0.45 log units) above it; measured number inside the range.
By their numbers in this assay, from the lowest: compounds 1 and 4 (each within the scatter of the next); then compounds 2 and 3 (each within the scatter of the next).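

In this assay, compound 4 breaks the earlier picture, in which a halogen on the phenyl set a compound apart from the bare phenyl of compound 1: a 1.7-fold higher number from compound 1 to compound 4 (0.24 log units; within the scatter), so 2-bromophenyl cannot be told apart from that phenyl, and only 4-fluorophenyl and 4-chlorophenyl show a separation. The identity of this aryl group therefore matters more than the fluoro-to-chloro exchange suggested, for a 4.2-fold lower number from compound 3 to compound 4 (0.62 log units; beyond the scatter) and a 2.8-fold lower number from compound 2 to compound 4 (0.45 log units; beyond the scatter) both lie beyond the scatter, whereas a 1.5-fold higher number from compound 2 to compound 3 (0.18 log units; within the scatter) does not. Nothing available here accounts for this difference between 2-bromophenyl and the two other halogenated phenyl groups.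

The change to compound 4 alters both the halogen and its place on the phenyl, so these compounds leave open which of the two matters, a question that 4-bromophenyl and 2-chlorophenyl analogues would address. They also leave open how this position responds to groups other than halogens, such as a methoxy group, an amine or a carboxylic acid on the phenyl.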